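This account rests on a few compounds, and the source may have more. Where it says the series, first, only, none or still open, it means among the compounds named here.

Of the compounds shown here, three have been measured: compound 1 `COc1cc(/C=C/C(=O)NNC(=O)c2ccccc2)ccc1O`, compound 2 `O=C(/C=C/c1ccc(O)c(O)c1)NNC(=O)c1ccccc1` and compound 3 `COc1ccc(C(=O)NNC(=O)/C=C/c2cc(OC)c(O)c(OC)c2)cc1`. In a functional assay on H184B5F5/M10 cells (Homo sapiens) for antiproliferative activity, read by MTT assay, with a stated time of 24 h (a higher number here means a weaker inhibitor, a lower number a stronger inhibitor), compound 1 gives 9170 nM, compound 2 gives 8120 nM and compound 3 gives 9450 nM.

Compound 1 and compound 2 differ in a single place, (hydrogen in place of methyl on an oxygen on an aromatic ring), and this change made a 1.1-fold lower number from compound 1 to compound 2 (0.05 log units; within the scatter). Compound 3 rests on a different core; the difference between the two cores is not broken down here. What the two values show is that compound 3 and compound 1 sit close together in this assay, with their gap within the usual scatter.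

Compound 4 `COc1cc(/C=C/C(=O)NNC(=O)c2ccc(O)cc2)cc(OC)c1O` has not yet been measured. It differs from compound 3 by hydrogen in place of methyl on an oxygen on an aromatic ring, the same change as from compound 1 to compound 2, and in both cases the place is an oxygen on an aromatic ring whose other neighbours are aromatic carbon. Because the step of a 1.1-fold lower number from compound 1 to compound 2 (0.05 log units; within the scatter) stayed within the scatter, the expected step from compound 3 to compound 4 is likewise small, a 1.1-fold lower number from compound 3 to compound 4 (0.04 log units; within the scatter). Compound 4 is therefore estimated at 8600 nM, with a likely span from 4300 nM to 17000 nM.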

Compound 4, half-maximal inhibitory concentration: > 10000 nM
Compound 4 gave a limit, no number; the forecaster's own chance of this, stated with the estimate: 5%; middle value at least 1.1-fold (0.06 log units) from the limit.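

In this assay compound 4 gives > 10000 nM, which is a limit of the assay and not a number. On these data alone, the step can therefore be read only as a lower bound, an at least 1.0-fold higher number from compound 3 to compound 4 (0.02 log units; that floor lies within the scatter), and how large it really is remains unknown. The change of methoxy to hydroxy has now been met on two cores, but the data neither show that it carries over unchanged from the core of compound 1 to the core of compound 3 nor show that it behaves differently there: the same change on two cores in this assay, a 1.1-fold lower number (0.05 log units; within the scatter) from compound 1 to compound 2 and an at least 1.0-fold higher number (0.02 log units; that floor lies within the scatter) from compound 3 to compound 4; the limit leaves it open whether they differ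

The compounds shown carry only hydroxy and methoxy groups on their aromatic rings, and it stays open how an amine or a carboxylic acid at that place on the ring would read in this assay. As far as these compounds go, it also stays open whether a longer chain on that oxygen, such as ethoxy in place of methoxy, would shift the value on either core.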